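A few compounds are considered here, and "the series" means these few. Any claim that something is new, unique, unknown or untested is made for them only; others in the source may bear on it.

Working notes on the series. In a functional assay on MGC-803 cells (Homo sapiens) for inhibition, read by MTT assay, with a stated time of 48 h (on this read-out higher numbers stand for weaker inhibition and lower numbers for stronger inhibition), compound 1 (`COc1ccc(CNc2cc(OC)c(OC)c(OC)c2)cc1Cl`) gives 46200 nM. Compound 3 (`COc1ccc(N(Cc2cc(OC)c(OC)c(OC)c2)C(=O)CCl)cc1O`) gives 24500 nM, and this number lies within the scatter of the number for compound 1, so the two cannot be told apart. Compound 2 (`C/C=C/C(=O)N(Cc1ccc(OC)c(N)c1)c1cc(OC)c(OC)c(OC)c1`) gives 150 nM, a far lower number that stands for stronger inhibition and lies beyond the scatter of both others.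

Compound 4 (`COc1ccc(CNc2cc(OC)c(OC)c(OC)c2)cc1`) has not yet been measured. It departs from compound 1 in one place: hydrogen in place of chloro on an aromatic carbon. In words, hydrogen stands in place of chloro on an aromatic carbon.

For the measured compounds named here, no two measured compounds differ in one place only, so the data hold no direct measure of this change. Compound 2 and compound 3 each differ from compound 1 in several places and offer little guidance here. With compound 1 at 46200 nM as the only close reference, no step beyond the scatter is expected in this assay, in either direction. The expected size of the step, a 1.2-fold lower number from compound 1 to compound 4 (0.06 log units; within the scatter), is therefore small. For compound 4 the estimate is 40000 nM, with an expected range of 12000 nM to 120000 nM.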

Compound 4, half-maximal inhibitory concentration: 11400 nM
For compound 4 the middle estimate is 3.5-fold (0.55 log units) above the measured one, and the stated range ends above it.
By their numbers in this assay, from the lowest: compound 2; then compound 4; then compounds 3 and 1 (each within the scatter of the next).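

Hydrogen in place of chloro gives a 4.1-fold lower number from compound 1 to compound 4 (0.61 log units; beyond the scatter) in this assay and so provides the first direct reading at this position, which the earlier compounds could not give. The aromatic carbon ortho to a methoxy group is not indifferent to what it carries: with the rest of the molecule unchanged, the loss of this one chlorine atom goes with stronger inhibition, although the step is modest. Nothing in hand accounts for this step, so the pair gives its direction and size but no explanation.

Whether chloro is unfavourable in particular or any group on this carbon would cost inhibition remains open, as the compounds shown offer only one substituent to set against hydrogen, and fluoro, bromo or methyl at this carbon would separate these readings. Also open, on these data alone, is whether the same change would give a step of similar size in compounds where the linking nitrogen carries an acyl group, as a single pair speaks only for the shared core of compound 1 and compound 4.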